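The compounds below may be only part of what the source reports. "The series", "measured", "known", "first", "only" and "open" are said of these compounds alone.

Measured compounds:
- Compound 1, `CC(C)c1nnsc1C[S+]([O-])C(c1ccccc1)c1ccccc1`: 69100 nM
- Compound 2, `[O-][S+](Cc1cccs1)C(c1ccc(Cl)cc1)c1ccc(Cl)cc1`: 7200 nM

Of the two compounds tested in an assay on HEK293 cells for inhibition of sodium-dependent dopamine transporter (Homo sapiens), read by scintillation counting, with stated times of 5 min and 1 min (a lower number here means a stronger inhibitor, a higher number a weaker inhibitor), compound 1 has the higher number, and the gap to compound 2 lies beyond the usual scatter. Compound 3, `Cc1cc(O)nc(C[S+]([O-])C(c2ccccc2)c2ccccc2)n1`, keeps the core of compound 1 and differs in one place: 4-hydroxy-6-methylpyrimidin-2-yl in place of 4-isopropyl-1,2,3-thiadiazol-5-yl on a saturated chain carbon bound to a sulfur. Going by the values given here, no pair of measured compounds shows what such a swap does here, so the step from compound 1 to compound 3 is expected to stay within the scatter, with no clear direction. For compound 3 the expected value in this assay is 60000 nM, in a range from 12000 nM to 250000 nM, an expected step of a 1.2-fold lower number from compound 1 to compound 3 (0.06 log units; within the scatter).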

Compound 3, half-maximal inhibitory concentration: 109000 nM
Compound 3: middle estimate off by 1.8-fold (0.26 log units), on the low side, within the range that was stated.
By their numbers in this assay, from the lowest: compound 2; then compounds 1 and 3 (each within the scatter of the next).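

Putting 4-hydroxy-6-methylpyrimidin-2-yl in place of 4-isopropyl-1,2,3-thiadiazol-5-yl on a saturated chain carbon bound to a sulfur gives a 1.6-fold higher number from compound 1 to compound 3 (0.20 log units; within the scatter) in this assay. At this position, then, a five-membered aromatic ring with 3 hetero atoms and a six-membered aromatic ring with 2 hetero atoms and a hydrogen-bond donor cannot be told apart in this measurement. No outside data explain this result. As far as these compounds go, whether a non-ring group here, such as an amine or a carboxylic acid, would give a step beyond the scatter remains open.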